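Carbonyl-side change from compound 3 to compound 4

The compounds below may be only part of what the source reports. "The series", "measured", "known", "first", "only" and "open" are said of these compounds alone.

Measured compounds in an assay on HEK293 cells for negative allosteric modulation of metabotropic glutamate receptor 5 (Homo sapiens), read by FLIPR; a higher number here means a weaker inhibitor, a lower number a stronger inhibitor:
Compound 1 `O=C(C1CCC(F)(F)CC1)N1CC(c2nc(-c3cccc(Cl)c3)no2)C1` gives > 10000 nM, a limit of the assay.
Compound 2 `Cc1cccc(-c2noc(C3CN(C(=O)C4CCC(C(F)(F)F)CC4)C3)n2)c1` gives > 10000 nM, a limit of the assay.
Compound 3 `O=C(C1CCC2(CCC2)CC1)N1CC(c2nc(-c3cccc(Cl)c3)no2)C1` gives > 10000 nM, a limit of the assay.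

Compound 3 thus stands at the limit, as does every value shown (the limit of > 10000 nM in this assay, at which 3 of the 3 values shown sit). Compound 4 `COC1CCN(C(=O)N2CC(c3nc(-c4cccc(Cl)c4)no3)C2)CC1` differs from compound 3 at the carbonyl carbon: a group of 8 heavy atoms (6 carbon, 1 nitrogen, 1 oxygen; one six-membered non-aromatic ring with 1 hetero atom) in place of a group of 9 heavy atoms (9 carbon; one four-membered non-aromatic ring of carbon only, one six-membered non-aromatic ring of carbon only), on a carbonyl carbon. Within the data shown here, the one measured step at the same place, a step that the two limits leave unreadable from compound 1 to compound 3, runs between two limits and is not readable, so nothing measured fixes the size or direction of the change. With all values shown at the limit, compound 4 is expected to sit near it too, with a step estimated at a step that the limit leaves unreadable from compound 3 to compound 4. Compound 4 is estimated at 12000 nM, in the range 3000 nM to 40000 nM, most likely reported again as a limit.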

Compound 4, half-maximal inhibitory concentration: > 10000 nM
Compound 4: no number, only a limit (the forecaster's own chance of this, stated with the estimate: 70%); the middle value does not contradict the limit.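

In this assay compound 4 gives > 10000 nM, a limit of the assay, so the steps to it from compound 1 and compound 3 cannot be read. The compounds shown leave open whether any group on the carbonyl carbon gives a measurable value, as all stand at one limit: the limit of > 10000 nM in this assay, at which 4 of the 4 values shown sit.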